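Moving compound 2 off its assay limit

A few compounds are considered here, and "the series" means these few. Any claim that something is new, unique, unknown or untested is made for them only; others in the source may bear on it.

Compound 1 `O=[N+]([O-])c1ccc(-c2csc(N/N=C/c3ccc(C(F)(F)F)cc3)n2)cc1`: 7410 nM
Compound 2 `COc1ccc(-c2csc(N/N=C/c3ccc(C(F)(F)F)cc3)n2)cc1`: > 66100 nM (a limit)

In a functional assay on NCI-H292 cells (Homo sapiens) for inhibition, read by MTT assay, with a stated time of 72 h (a lower number here means a stronger inhibitor, a higher number a weaker inhibitor), compound 1 gives 7410 nM. Compound 2 stands at the limit of > 66100 nM in this assay, at which 1 of the 2 values shown sits, and this is a limit, not a number.

The next structure is compound 3 `FC(F)(F)c1ccc(/C=N/Nc2nc(-c3ccc(Cl)c(Cl)c3)cs2)cc1`, with 3,4-dichlorophenyl in place of 4-methoxyphenyl on an aromatic carbon of a five-membered aromatic ring with 1 nitrogen and 1 sulfur: 3,4-dichlorophenyl in place of 4-methoxyphenyl on an aromatic carbon.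

Among the compounds with values here, one measured step bears on this change, as it also concerns the methoxy group of compound 2: an at least 8.9-fold higher number from compound 1 to compound 2 (0.95 log units; beyond the scatter), which is beyond the scatter. Within the data shown here, only one pair supports this reading, so the transfer to a different aromatic group is uncertain. Even so, a step of similar size, toward a lower number, is expected in this assay, with compound 1 at 7410 nM as the guide. The estimated change is an at least 6.0-fold lower number from compound 2 to compound 3 (0.77 log units; beyond the scatter). For compound 3 the expected value is 11000 nM, with an estimated range from 3000 nM to 45000 nM.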

Compound 3, half-maximal inhibitory concentration: 6570 nM
Compound 3: the middle estimate sits 1.7-fold (0.22 log units) above what was measured; low and high end bracket the measured number.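

On the aromatic carbon next to the ring nitrogen, the weak result of compound 2 does not extend to every replacement of 4-nitrophenyl: in this assay, 3,4-dichlorophenyl in place of 4-methoxyphenyl gives a clear gain (an at least 10-fold lower number from compound 2 to compound 3 (1.00 log units; beyond the scatter)). A nitro group is also not required for the level of compound 1, as the change from 4-nitrophenyl to 3,4-dichlorophenyl leaves the two compounds indistinguishable (a 1.1-fold lower number from compound 1 to compound 3 (0.05 log units; within the scatter)), and among the three aryl groups shown, compound 2 is the one that stands apart. Compound 2 is held only as a limit and not as a number, so the step to compound 3 has a minimum size and no exact one: the limit of > 66100 nM in this assay, at which 1 of the 3 values shown sits.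

From the compounds shown here alone, it remains open whether 4-methoxyphenyl is an isolated exception or part of a wider trend, which 4-aminophenyl, 4-carboxyphenyl or a single 4-chlorophenyl at this carbon would help to settle. Going by these compounds, the 4-trifluoromethylphenyl end is also constant across the three compounds, so it is unknown whether these differences would persist with a nitrile or an amine in place of the trifluoromethyl group.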